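Adding a second chloro to compound 1

A few compounds are considered here, and "the series" means these few. Any claim that something is new, unique, unknown or untested is made for them only; others in the source may bear on it.

Compound 1 (`CCn1c(=O)cc(Cl)[s+]1[O-]`): > 100000 nM as a limit
Compound 2 (`COC(=O)CCn1c(=O)cc(Cl)[s+]1[O-]`): > 100000 nM as a limit
Compound 3 (`COC(=O)CCn1sc(Cl)c(Cl)c1=O`): 16000 nM

All of these readings come from a functional assay on HepG2 cells (Homo sapiens) for inhibition, read by crystal violet staining, with a stated time of 48 h (on this read-out higher numbers stand for weaker inhibition and lower numbers for stronger inhibition), and they frame the question of compound 4 (`CCn1c(=O)c(Cl)c(Cl)[s+]1[O-]`), which has yet to be measured. Compound 1 sits at the limit of > 100000 nM in this assay, at which 2 of the 3 values shown sit, and so has a limit rather than a number. Going by the values given here, the one measured step is a step that the two limits leave unreadable from compound 1 to compound 2 and it gives no size to carry over.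

Compound 4 keeps the core of compound 1, and the change is chloro in place of hydrogen on an aromatic carbon. In short, it is chloro in place of hydrogen on an aromatic carbon.

Among the compounds with values here, no measured step isolates this change. Within the data shown here, the only guide is compound 3 at 16000 nM, which also carries chloro on that aromatic carbon, though no step leads to it from compound 1. A move towards stronger inhibition, meaning a lower number, is therefore expected, but only tentatively. The estimated step is an at least 2.0-fold lower number from compound 1 to compound 4 (0.30 log units; that floor lies within the scatter) and its size is highly uncertain. Compound 4 is estimated at 50000 nM with an expected range from 15000 nM to 100000 nM and the assay may still report only a limit.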

Compound 4, half-maximal inhibitory concentration: > 100000 nM
Compound 4 gave a limit, no number; the forecaster's own chance of this, stated with the estimate: 45%; middle value at least 2.0-fold (0.30 log units) away from the limit.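

In this assay compound 4 gives > 100000 nM, which is a limit and not a number. Compound 1 also has only a limit, so no step between the two can be read, and both stand at the same edge: the limit of > 100000 nM in this assay, at which 3 of the 4 values shown sit.

The compounds shown leave open whether chloro in place of hydrogen on this aromatic carbon changes inhibition on the core of compound 1 at all, and by how much.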